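Compound 3 to compound 4: a phenyl swap at a limit

This account rests on a few compounds, and the source may have more. Where it says the series, first, only, none or still open, it means among the compounds named here.

In an ADME assay on MCF-10A cells (Homo sapiens) for inhibition, with a stated time of 48 h (on this read-out higher numbers stand for weaker inhibition and lower numbers for stronger inhibition), compound 1 (`O=C(Nc1ccc(I)cc1)N1CCC[C@H]1c1nc(-c2ccccc2)no1`) reads > 50000 nM as a limit and not a number. Compound 2 (`N#Cc1ccc(NC(=O)N2CCC[C@H]2c2nc(-c3ccccc3)no2)cc1`) reads > 50000 nM in this assay as a limit too. Compound 3 (`O=C(Nc1ccc(Cl)cc1)N1CCC[C@H]1c1nc(-c2cccc(F)c2)no1`) also reads > 50000 nM as a limit, so the starting point of this step is not a number. The whole set comes down to the limit of > 50000 nM in this assay, at which 3 of the 3 values shown sit, and no measured number lies among them.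

Compound 4 (`O=C(Nc1ccc(Cl)cc1)N1CCC[C@H]1c1nc(-c2ccc(Br)cc2)no1`) carries 4-bromophenyl in place of 3-fluorophenyl on an aromatic carbon of the five-membered aromatic ring with 2 nitrogen and 1 oxygen, with 4-bromophenyl in place of 3-fluorophenyl on an aromatic carbon as the counted difference.

Among the measured compounds shown here, the one measured step available is a step that the two limits leave unreadable from compound 1 to compound 2 for cyano in place of iodo on an aromatic carbon. It offers no size to carry over, and no direction can be drawn from it. The expectation therefore rests on the shared limit alone, with no change beyond the scatter foreseen. The expected step is a step that the limit leaves unreadable from compound 3 to compound 4 with no direction favoured. For compound 4 the estimate is 60000 nM with an expected range from 30000 nM to 100000 nM and a further limit is the likeliest report.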

Compound 4, half-maximal inhibitory concentration: > 50000 nM
Compound 4: a limit, no number; the forecaster's own chance of this, stated with the estimate: 85%; the middle value is on the limit's open side.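

Compound 3 and compound 4 both report a limit and not a number in this assay, so no step can be read between them. Every value shown remains a limit: the limit of > 50000 nM in this assay, at which 4 of the 4 values shown sit. The compounds shown leave open whether any change on the shared core would give a measured number in this assay.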